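This account rests on a few compounds, and the source may have more. Where it says the series, first, only, none or still open, it means among the compounds named here.

Working notes on a small series in a functional assay on Ehrlich cells (Mus musculus) for cytotoxicity, tested at 10 ug/mL; on this read-out higher numbers stand for a stronger effect at the one concentration tested and lower numbers for a weaker effect. Compound 1 `COc1cc(N2C(N)=C(C#N)C(c3ccccc3O)C3=C2CC(C)(C)CC3=O)cc(OC)c1OC` gives 0%; compound 2 `COc1cc(N2C(N)=C(C#N)C(c3ccc(Cl)cc3Cl)C3=C2CC(C)(C)CC3=O)cc(OC)c1OC` gives 20%; compound 3 `COc1cc(N2C(N)=C(C#N)C(c3ccccc3Cl)C3=C2CC(C)(C)CC3=O)cc(OC)c1OC` gives 10%. Compound 3 stands second highest of the three numbers, nearest compound 1 and furthest compound 2, and both gaps lie within the scatter. Going by the values given here, the only step beyond the scatter is a number 20 percentage points higher from compound 1 to compound 2 (beyond the scatter). The two steps of a single aromatic substituent, a number 10 percentage points higher from compound 1 to compound 3 (within the scatter) and a number 10 percentage points lower from compound 2 to compound 3 (within the scatter), stay within it.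

Compound 4 `COc1cc(N2C(N)=C(C#N)C(c3ccc(O)cc3)C3=C2CC(C)(C)CC3=O)cc(OC)c1OC` differs from compound 3 by 4-hydroxyphenyl in place of 2-chlorophenyl on a saturated ring carbon. The step of a number 10 percentage points higher from compound 1 to compound 3 (within the scatter) bears most on this change, since it exchanged hydroxy for chloro on an aromatic carbon and stayed within the scatter; the step of a number 10 percentage points lower from compound 2 to compound 3 (within the scatter) shows that taking away one chloro also moved nothing beyond it. Among the compounds with values here, no measured compound carries a 4-hydroxyphenyl, so that part of the change has no precedent here. For compound 4 the expected step in this assay is a number 5 percentage points lower from compound 3 to compound 4 (within the scatter), not beyond the scatter. Compound 4 is estimated at 5%, within 0% to 20%.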

Compound 4, a percentage reported as activity, at one concentration (the size of the read-out at that concentration, not a potency): 10%
The estimate for compound 4 lay 5 percentage points below the measured number; the range from low to high includes it.
By their numbers in this assay, from the lowest: compounds 1, 3, 4 and 2 (each within the scatter of the next, the first and the last beyond it).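

In this assay, the place of the hydroxy on the phenyl ring at this saturated ring carbon does not separate 2-hydroxyphenyl from 4-hydroxyphenyl (a number 10 percentage points higher from compound 1 to compound 4 (within the scatter)). Nor does exchanging 2-chlorophenyl for 4-hydroxyphenyl, which adds a hydrogen-bond donor and acceptor, separate the two compounds (no change at the digits printed from compound 3 to compound 4 (within the scatter)). Going by these compounds alone, the 2,4-dichlorophenyl of compound 2 also stays within the scatter of 4-hydroxyphenyl (a number 10 percentage points lower from compound 2 to compound 4 (within the scatter)), so its only step beyond the scatter remains the one from compound 1, and nothing available explains these results. Open, from the compounds shown here alone, is whether an aminophenyl, a carboxyphenyl or a saturated cyclohexyl at this carbon would leave the read-out within this narrow band. With one concentration, the compounds shown also say nothing about potency.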